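Notes on the step from compound 3 to compound 4

This account rests on a few compounds, and the source may have more. Where it says the series, first, only, none or still open, it means among the compounds named here.

- compound 1 `N#Cc1c(O)nc(SCc2nc3ccccc3[nH]2)nc1-c1ccccc1` gives 7.7 nM
- compound 2 `N#Cc1c(Cl)nc(SCc2nc3ccccc3[nH]2)nc1-c1ccccc1` gives 3.28 nM
- compound 3 `CCNc1nc(SCc2nc3ccccc3[nH]2)nc(-c2ccccc2)c1C#N` gives 5.3 nM

All three values come from a functional assay on SK-MEL-28 cells (Homo sapiens) for cytotoxicity, read by MTT assay, with a stated time of 3 days (on this read-out higher numbers stand for weaker inhibition and lower numbers for stronger inhibition), and lie close together. Compound 3 stands within the scatter of both others, as shown by a 1.5-fold lower number from compound 1 to compound 3 (0.16 log units; within the scatter) and by a 1.6-fold higher number from compound 2 to compound 3 (0.21 log units; within the scatter) in turn. Only a 2.3-fold lower number from compound 1 to compound 2 (0.37 log units; beyond the scatter) passes beyond the scatter, and that step is modest.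

Compound 4 `N#Cc1c(NNC(N)=S)nc(SCc2nc3ccccc3[nH]2)nc1-c1ccccc1` has not been measured. The change is a group of 4 heavy atoms (1 carbon, 2 nitrogen, 1 sulfur; no ring) in place of a group of 2 heavy atoms (2 carbon; no ring), on a nitrogen on an aromatic ring on a nitrogen on an aromatic ring, so the ethyl leaves and a larger group without a ring enters. Among the measured compounds shown here, no measured step alters the ethyl alone, so the evidence is indirect. The three steps exchange hydroxy, chloro and ethylamino on an aromatic carbon, and in this small set those exchanges moved this assay little. A similarly small effect is therefore assumed, with a wide range to reflect the larger incoming group. The expected step is a 1.1-fold higher number from compound 3 to compound 4 (0.05 log units; within the scatter) and none beyond the scatter is foreseen in either direction. Compound 4 is estimated at 6 nM (expected range 2 nM to 18 nM).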

Compound 4, half-maximal inhibitory concentration: 3.2 nM
Compound 4: the middle estimate sits 1.9-fold (0.27 log units) above what was measured, within the range that was stated.
By their numbers in this assay, from the lowest: compounds 4, 2, 3 and 1 (each within the scatter of the next, the first and the last beyond it).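

In this assay, among the compounds shown here, this is the first change on the nitrogen itself rather than on the aromatic carbon, and replacing the ethyl with a larger group without a ring, one that carries hydrogen-bond donors and an acceptor, stays within the scatter (a 1.7-fold lower number from compound 3 to compound 4 (0.22 log units; within the scatter)), so this nitrogen tolerates the exchange. Against the groups on the aromatic carbon, compound 4 cannot be told apart from the chloro compound (a 1.0-fold lower number from compound 2 to compound 4 (0.01 log units; within the scatter)), while the step from the hydroxy compound is the only one of the three beyond the scatter and is modest (a 2.4-fold lower number from compound 1 to compound 4 (0.38 log units; beyond the scatter)). No measurement at hand bears on the reason for these values.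

A plain amino group, a hydrazinyl group or the oxygen counterpart of the entering group at this place would help show whether the sulfur-bearing end contributes anything to the read-out. Going by these compounds, it also remains open whether a longer alkyl chain on the same nitrogen would stay within the scatter of compound 3.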